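A few compounds are considered here, and "the series" means these few. Any claim that something is new, unique, unknown or untested is made for them only; others in the source may bear on it.

Measured so far:
- compound 1 `Cc1ccc(CN2CCc3cc(NC(=O)NCc4ccncc4)ccc32)cc1`: "not determined" (no result reported) in an assay on HEK293-A cells for activation of Nicotinamide phosphoribosyltransferase (Homo sapiens), tested at 3 uM; on this read-out lower numbers stand for a weaker effect and higher numbers for a stronger effect at the one concentration tested
- compound 2 `CC(C)c1nc2ccc(NC(=O)NCc3ccncc3)cn2n1`: 32% in this assay

Among the compounds with values here, compound 1 stands nowhere on the numbers: in this assay compound 1 has no result, so the only number is that of compound 2, which reaches 32% in this assay and shares only the urea-linked pyridinylmethyl part with compound 1. Compound 3 `Cc1ccc(C(=O)N2CCc3cc(NC(=O)NCc4ccncc4)ccc32)cc1` is the next entry. It differs from compound 1 in one place: (4-methylphenyl)carbonyl in place of 4-methylbenzyl on a nitrogen on an aromatic ring in a ring. The (4-methylphenyl)carbonyl group carries one hydrogen-bond acceptor and one double bond outside aromatic rings where the 4-methylbenzyl group carries none. Within the data shown here, without a value for compound 1 no step can be computed, and no measured pair shows what such a change does in this assay; any shift is expected to be modest, of a size that could fall within the scatter or somewhat beyond it in either direction. On this basis compound 3 is expected to give about 30% in this assay, within 5% to 60%.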

Compound 3, a percentage reported as activity, at one concentration (the size of the read-out at that concentration, not a potency): 45%
Compound 3: middle estimate off by 15 percentage points, on the low side, and the stated range covers the measured number.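

Within the data shown here, with compound 1 at "not determined" (no result reported) in this assay, no step to compound 3 can be read. The compounds shown leave open what replacing 4-methylbenzyl with (4-methylphenyl)carbonyl does in this assay. No supporting evidence bears on this result.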